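Indole attachment and methylation in the trimethoxyphenyl series

A few compounds are considered here, and "the series" means these few. Any claim that something is new, unique, unknown or untested is made for them only; others in the source may bear on it.

In a functional assay on A549 cells (Homo sapiens) for inhibition, read by CCK-8 assay, with a stated time of 48 h (a lower number here means a stronger inhibitor, a higher number a weaker inhibitor), the reference points are three measured compounds on a shared core. Compound 1 `COc1cc(-c2ccnc3c(-c4ccc(C)cc4)cnn23)cc(OC)c1OC` returns only a limit, > 10000 nM, which is the assay limit and not a number (the limit of > 10000 nM in this assay, at which 1 of the 3 values shown sits). Compound 2 `COc1cc(-c2ccnc3cc(-c4ccc(C(C)=O)cc4)nn23)cc(OC)c1OC` gives 4100 nM. Compound 3 `COc1cc(-c2ccnc3cc(-c4c[nH]c5ccccc45)nn23)cc(OC)c1OC` gives 29 nM, the lowest of the two numbers shown, with compound 2 as its nearest neighbour.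

Among the compounds with values here, the one measured step that bears on the indole region is a 140-fold lower number from compound 2 to compound 3 (2.15 log units; beyond the scatter), which shows that the group at this position carries a large part of the activity.

Compound 4 `COc1cc(-c2ccnc3cc(-c4ccc5c(ccn5C)c4)nn23)cc(OC)c1OC` is not yet measured. It differs from compound 3 by 1-methyl-1H-indol-5-yl in place of 1H-indol-3-yl on an aromatic carbon. Within the data shown here, no measured step isolates either the change of attachment point or the methylation of the indole nitrogen, so the expectation rests only on the weight that a 140-fold lower number from compound 2 to compound 3 (2.15 log units; beyond the scatter) places on this group. A loss of some potency toward the range of compound 2 seems more likely than a gain, without reaching it. The expected step is a 6.9-fold higher number from compound 3 to compound 4 (0.84 log units; beyond the scatter). Compound 4 is therefore estimated at 200 nM, with a plausible range from 40 nM to 1500 nM.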

Compound 4, half-maximal inhibitory concentration: 15 nM
Estimate against measurement, compound 4: 13-fold (1.12 log units) above; the measured number lies below the stated range.
By their numbers in this assay, from the lowest: compounds 4 and 3 (each within the scatter of the next); then compound 2. At a limit, above all of these: compound 1.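

In this assay, replacing 1H-indol-3-yl with 1-methyl-1H-indol-5-yl gives a 1.9-fold lower number from compound 3 to compound 4 (0.29 log units; within the scatter), so the change of attachment point and the methylation of the indole nitrogen, taken together, leave the two numbers unresolved, even though the entering group lacks the hydrogen-bond donor of the group it replaces. The large step seen with the first indole also appears with the second, as a 270-fold lower number from compound 2 to compound 4 (2.44 log units; beyond the scatter), so among the compounds shown, high potency at this position depends neither on the 3-yl attachment nor on a free indole nitrogen hydrogen. Nothing measured here explains why these two indoles give such similar numbers.

Compound 4 carries both changes at once, so the effects of attachment point and methylation remain unseparated, and 1H-indol-5-yl and 1-methyl-1H-indol-3-yl would each isolate one of them. Also open, as far as these compounds go, is how this position responds to other groups on the indole, such as an amine or a carboxylic acid on its six-membered ring, or a longer chain in place of the methyl on its nitrogen.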